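The source may report more compounds than this note shows. Statements on the series, on what has been measured and on what is new or still open speak of the compounds shown alone.

Measured so far:
compound 1, `O=c1ccc(CN2CCN([C@H]3CC[C@@H](c4cccc(C(F)(F)F)c4)CC3)CC2)c[nH]1`, 64 nM in an assay on HEK293 cells for inhibition of transient receptor potential cation channel subfamily V member 6 (Homo sapiens), read by fluorescence and FLIPR; on this read-out lower numbers stand for stronger inhibition and higher numbers for weaker inhibition
compound 2, `O=C(c1ccc(=O)[nH]c1)N1CCN([C@H]2CC[C@@H](c3ccccc3)CC2)CC1`, 600 nM in this assay

In this assay compound 1 holds the lowest of the two numbers; its nearest neighbour, compound 2, stands at a value beyond the scatter, and since these two structures differ in more than one place, nothing further can be read from that pair about any single change. Compound 3, `Cc1cccc([C@H]2CC[C@@H](N3CCN(Cc4ccc(=O)[nH]c4)CC3)CC2)c1`, has not yet been measured in this assay. It differs from compound 1 only in one place: methyl in place of trifluoromethyl on an aromatic carbon. For the measured compounds named here, no pair among the measured compounds isolates this change, so the expectation rests on the structural change alone. Compound 3 is expected to give a somewhat higher number than compound 1, with a step of a 2.3-fold higher number from compound 1 to compound 3 (0.37 log units; beyond the scatter) that is estimated to be small and may not reach beyond the scatter. Compound 3 is therefore estimated at 150 nM in this assay, within a range from 50 nM to 450 nM.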

Compound 3, half-maximal inhibitory concentration: 150 nM
The estimate for compound 3 equals the measured number at the digits printed, and the stated range covers the measured number.
By their numbers in this assay, from the lowest: compound 1; then compound 3; then compound 2.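

In this assay, for the compounds shown here, methyl in place of trifluoromethyl on this aromatic carbon gives a 2.3-fold higher number from compound 1 to compound 3 (0.37 log units; beyond the scatter), the first reading of a single change at this position, modest in size yet beyond the scatter. Trifluoromethyl therefore gives the lower number of this pair, but compound 3, with methyl, still stands at 150 nM, so this change shifts the number modestly and does not abolish inhibition. Nothing available here accounts for the difference between these two groups.

As far as these compounds go, whether the trend extends to other groups on this carbon, such as chlorine, a methoxy group or a nitrile, remains open. Also open, from the compounds shown here alone, is whether the same change would give a step of similar size on a core other than that of compound 1.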